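Notes on the amide substituent series in a cell assay

This account rests on a few compounds, and the source may have more. Where it says the series, first, only, none or still open, it means among the compounds named here.

Measured so far:
compound 1 `COc1cccc(OC)c1C(=O)Nc1c[nH]nc1C(=O)Nc1ccncc1`: > 50000 nM in an ADME assay on MRC5 cells (Homo sapiens) for inhibition, with a stated time of 72 h; a lower number here means that less compound is needed, a higher number that more compound is needed for the effect
compound 2 `COc1cccc(OC)c1C(=O)Nc1c[nH]nc1C(=O)O`: > 50000 nM
compound 3 `COc1cccc(OC)c1C(=O)Nc1c[nH]nc1C(=O)NCc1ncccc1C`: > 50000 nM

Compound 3 stands only at a limit in this assay: its value of > 50000 nM is a limit of the assay and not a number. Among the measured compounds shown here, the same holds for the other two compounds, so all three sit at the limit of > 50000 nM in this assay, at which 3 of the 3 values shown sit, and no compound in the set can be ordered against another.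

The next compound is compound 4 `COc1cccc(OC)c1C(=O)Nc1c[nH]nc1C(=O)NC1CCC(C)CC1`. It differs from compound 3 in one place: 4-methylcyclohexyl in place of (3-methylpyridin-2-yl)methyl on an amide-type nitrogen.

The measured steps that touch the same place are the change from compound 1 to compound 3, a step that the two limits leave unreadable from compound 1 to compound 3, and the change from compound 2 to compound 3, a step that the two limits leave unreadable from compound 2 to compound 3; the remaining step, a step that the two limits leave unreadable from compound 1 to compound 2, is equally unreadable. None of them gives a size, so no step in either direction beyond the scatter can be expected for compound 4 on these data, and the most likely outcome is once more a limit.

The estimate for compound 4 in this assay is therefore 50000 nM, with a range from 20000 nM to 100000 nM, which is expected to mean a step of a number no higher from compound 3 to compound 4 (the limit leaves the size open).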

Compound 4, half-maximal effective concentration: 45000 nM
Beside the measured number, compound 4's estimate is 1.1-fold (0.05 log units) above it; the range from low to high includes it.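

In this assay, among the compounds shown here, compound 4 gives 45000 nM, the first number rather than a limit, so a value can be read with 4-methylcyclohexyl on the amide-type nitrogen. The change on that nitrogen reads as an at least 1.1-fold lower number from compound 3 to compound 4 (0.04 log units; that floor lies within the scatter) and as an at least 1.1-fold lower number from compound 1 to compound 4 (0.04 log units; that floor lies within the scatter), while the change on the carbonyl carbon reads as an at least 1.1-fold lower number from compound 2 to compound 4 (0.04 log units; that floor lies within the scatter); each of these is only a floor, so no effect beyond the scatter is shown and the true sizes stay open. The steps among compound 1, compound 2 and compound 3 cannot be read, and the values of those three compounds are each a limit of the assay: the limit of > 50000 nM in this assay, at which 3 of the 4 values shown sit.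

Compound 4 combines two differences in one step, as the ring nitrogen leaves and a non-aromatic ring of carbon only enters, and the compounds shown do not separate them. Also open, on these data alone, is whether plain cyclohexyl, phenyl or a longer alkyl chain on the same amide-type nitrogen would give a number that stands beyond the scatter from compound 4.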